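Methoxy on the amide-ring phenyl: expected activity

A few compounds are considered here, and "the series" means these few. Any claim that something is new, unique, unknown or untested is made for them only; others in the source may bear on it.

Compound 2 `CC(C)[C@@H]1CC[C@@H](C)C[C@@]12N(C)C(=O)[C@@H]1[C@H]3C(=O)N(c4ccccc4)C(=O)[C@H]3ON12` stands highest of the two numbers in a functional assay, read by spectrophotometry, with a stated time of 2 h, tested at 3 mg/mL (a lower number here means a weaker effect, a higher number a stronger effect of the compound at the concentration tested), giving 58.9%. Its nearest neighbour, compound 1 `CC(C)[C@@H]1CC[C@@H](C)C[C@@]12N(C)C(=O)[C@@H]1[C@H]3C(=O)NC(=O)[C@H]3ON12`, gives 47.3% in this assay, and the step of a number 11.6 percentage points higher from compound 1 to compound 2 (beyond the scatter) is the only one measured. Compound 3 `COc1ccc(N2C(=O)[C@H]3[C@H](ON4[C@@H]3C(=O)N(C)[C@@]43C[C@H](C)CC[C@H]3C(C)C)C2=O)cc1` differs from compound 2 by methoxy in place of hydrogen on an aromatic carbon. Among the compounds with values here, no measured step bears on this change, and the one known step alters a different place, so it gives no direction. The step of a number 1.1 percentage points higher from compound 2 to compound 3 (within the scatter) is therefore expected to lie within the scatter. For compound 3 an activity of 60% is estimated in this assay, between 45% and 75%.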

Compound 3, a percentage reported as activity, at one concentration (the size of the read-out at that concentration, not a potency): 67.7%
The estimate for compound 3 lay 7.7 percentage points below the measured number; low and high end bracket the measured number.
By their numbers in this assay, from the lowest: compound 1; then compounds 2 and 3 (each within the scatter of the next).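

In this assay, methoxy on an aromatic carbon, para to a large group, leaves the read-out within the scatter (a number 8.8 percentage points higher from compound 2 to compound 3 (within the scatter)), so phenyl and 4-methoxyphenyl cannot be told apart here. On the amide-type nitrogen in a ring, 4-methoxyphenyl in place of hydrogen also gives a gain beyond the scatter (a number 20.4 percentage points higher from compound 1 to compound 3 (beyond the scatter)), so that gain is not confined to plain phenyl. Nothing available explains either step.

On these data alone, whether an amine or a carboxylic acid at this same carbon of the phenyl would behave like methoxy remains open. Also open, as far as these compounds go, is whether a longer chain on the ring nitrogen could replace the aromatic ring.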